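The source may hold more compounds than are shown below. What is called first, only, known or untested is meant among the compounds shown, and "the series" means these compounds.

Measured so far:
compound 1, `COc1cc2c(cc1OC)C(c1ccc(Br)cc1)=NN(C)C(=S)C2`: 105 umol/kg
compound 2, `COc1cc2c(cc1OC)C(c1ccc(N)cc1)=NNC(=O)C2`: 15 umol/kg

In a functional assay on the whole organism with Mus musculus as the target (a higher number here means that more compound is needed for the effect, a lower number that less compound is needed), compound 1 gives 105 umol/kg, the higher of the two numbers seen; compound 2 gives 15 umol/kg. Compound 3, `COc1cc2c(cc1OC)C(c1ccc([N+](=O)[O-])cc1)=NN(C)C(=S)C2`, is not yet measured. It differs from compound 1 in one place: nitro in place of bromo on an aromatic carbon. Within the data shown here, no step between two measured compounds isolates such a change, so the direction is uncertain. The step from compound 1 to compound 3 in this assay is expected to be small, a 1.1-fold lower number from compound 1 to compound 3 (0.02 log units; within the scatter), within the usual scatter. For compound 3 the estimate is 100 umol/kg, with a range from 40 umol/kg to 250 umol/kg.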

Compound 3, dose for half-maximal effect: 103 umol/kg
Beside the measured number, compound 3's estimate is 1.0-fold (0.01 log units) below it; measured number inside the range.
By their numbers in this assay, from the lowest: compound 2; then compounds 3 and 1 (each within the scatter of the next).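

In this assay, putting nitro in place of bromo on this aromatic carbon, para to a large group, gives a 1.0-fold lower number from compound 1 to compound 3 (0.01 log units; within the scatter) and so leaves the two compounds indistinguishable. Among these compounds, this is the first direct reading at this position: a group of three heavy atoms with two hydrogen-bond acceptors reads the same as a single bromine with none. Nothing available accounts for this match. On these data alone, what a carboxylic acid or a longer alkyl chain on this carbon would give remains open. So does whether bromo and nitro would still match on a different core.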